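The source may report more compounds than this note shows. Statements on the series, on what has been measured and on what is new or still open speak of the compounds shown alone.

Compound 1 `COc1ccc(/C=C\C(=O)O)c(OCc2cn(-c3ccc(NC(C)=O)cc3)nn2)c1CC=C(C)C` is the weaker of the two compounds that returned a number in a functional assay on NCI-H322 cells (Homo sapiens) for cytotoxicity, read by MTT assay, with a stated time of 24 h (on this read-out lower numbers stand for stronger inhibition and higher numbers for weaker inhibition), where compound 1 gives 45700 nM. Its closest neighbour, compound 3 `COc1ccc(/C=C\C(=O)O)c(OCc2cn(-c3ccc(C#N)cc3)nn2)c1CC=C(C)C`, gives 18600 nM in this assay, and the step of a 2.5-fold lower number from compound 1 to compound 3 (0.39 log units; beyond the scatter) shows that swapping the group on this aromatic nitrogen moves the number only modestly. Compound 2 `COc1ccc(-n2cc(COc3c(/C=C\C(=O)O)ccc(OC)c3CC=C(C)C)nn2)cc1` has "not determined" (no result reported) in this assay, so it adds nothing to the comparison. Compound 4 `COc1ccc(/C=C\C(=O)O)c(OCc2cn(-c3nc4ccccc4s3)nn2)c1CC=C(C)C` differs from compound 1 by 1,3-benzothiazol-2-yl in place of 4-acetamidophenyl on an aromatic nitrogen. Going by the values given here, only the step from compound 1 to compound 3 bears on this change, and it was modest, so a modest move is expected here too. Compound 4 is therefore estimated at 22000 nM, within 7000 nM to 70000 nM, a step of a 2.1-fold lower number from compound 1 to compound 4 (0.32 log units; beyond the scatter).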

Compound 4, half-maximal inhibitory concentration: 23000 nM
For compound 4 the middle estimate is 1.0-fold (0.02 log units) below the measured one; measured number inside the range.
By their numbers in this assay, from the lowest: compounds 3, 4 and 1 (each within the scatter of the next, the first and the last beyond it).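

Swapping 4-acetamidophenyl for 1,3-benzothiazol-2-yl gives a 2.0-fold lower number from compound 1 to compound 4 (0.30 log units; within the scatter), and swapping 4-cyanophenyl for it gives a 1.2-fold higher number from compound 3 to compound 4 (0.09 log units; within the scatter). So this aromatic nitrogen can carry a group of two fused aromatic rings, not only a substituted phenyl, and the number stays within the scatter of both compound 1 and compound 3. No measurement here explains why these different groups give such close numbers.

On these data alone, whether an amine on the phenyl ring, or a plain longer carbon chain on this nitrogen in place of any aromatic ring, would keep the number in this range remains open.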